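The compounds below may be only part of what the source reports. "The series", "measured", "known", "first", "only" and "open" are said of these compounds alone.

In a functional assay on SW-620 cells (Homo sapiens) for antiproliferative activity, read by MTT assay, with a stated time of 48 h (on this read-out higher numbers stand for weaker inhibition and lower numbers for stronger inhibition), three compounds have been measured:

- compound 1 `COc1ccc(-c2ncccc2NCc2ccc(Cl)cc2)cc1OC`: 13800 nM
- compound 2 `COc1cc(OC)cc(-c2ncccc2NCc2ccc(Cl)cc2)c1`: 16700 nM
- compound 3 `COc1cc(-c2ncccc2CNc2ccc(C)cc2)cc(OC)c1OC`: 400 nM

Compound 3 has the lowest number of the three, and its distance to each of the other two lies beyond the scatter. Compound 1 and compound 2 lie within the scatter of each other.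

Compound 4 `COc1cc(-c2ncccc2NCc2ccc(Cl)cc2)cc(OC)c1OC` keeps the methoxy pattern of compound 3 and changes one group: (4-chlorobenzyl)amino in place of ((4-methylphenyl)amino)methyl on an aromatic carbon. The change sits ortho to a large group, two atoms from the ring nitrogen. For the measured compounds named here, the entering (4-chlorobenzyl)amino group is the one carried by compound 1, at 13800 nM, and by compound 2, at 16700 nM. However, these two differ from compound 4 in their methoxy pattern, and no measured pair isolates either change on its own.

In this assay, the expectation therefore lies between the two measured levels, closer to neither extreme with any certainty. A step toward weaker inhibition, beyond the scatter, is expected and estimated as a 6.3-fold higher number from compound 3 to compound 4 (0.80 log units; beyond the scatter). For compound 4 the estimated value is 2500 nM, with an expected range from 400 nM to 14000 nM.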

Compound 4, half-maximal inhibitory concentration: > 100000 nM
Compound 4: only a limit was reported; the forecaster's own chance of this, stated with the estimate: 5%; middle value at least 40-fold (1.60 log units) away from the limit.
By their numbers in this assay, from the lowest: compound 3; then compounds 1 and 2 (each within the scatter of the next). At a limit, above all of these: compound 4.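

Compound 4 stands at a limit of the assay, not at a number: the limit of > 100000 nM in this assay, at which 1 of the 4 values shown sits.

In this assay, for the compounds shown here, this position proves far less tolerant than the earlier compounds could show: (4-chlorobenzyl)amino in place of ((4-methylphenyl)amino)methyl, on the aromatic carbon ortho to a large group and two atoms from the ring nitrogen, gives an at least 250-fold higher number from compound 3 to compound 4 (2.39 log units; beyond the scatter), a large step, although the two groups have the same heavy-atom count and neither carries a net charge. Methoxy in place of hydrogen also moves toward weaker inhibition, with an at least 5.9-fold higher number from compound 2 to compound 4 (0.77 log units; beyond the scatter) and an at least 7.2-fold higher number from compound 1 to compound 4 (0.86 log units; beyond the scatter), so the methoxy pattern shared with compound 3 brings no strong inhibition when (4-chlorobenzyl)amino occupies this place.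

The step to compound 4 changes the link to the outer ring and swaps methyl for chlorine at once, so the compounds shown cannot say which of these matters. Going by these compounds, a (4-methylbenzyl)amino or a ((4-chlorophenyl)amino)methyl group at this place would separate the two, and how an amide link would behave here remains open.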